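The compounds below may be only part of what the source reports. "The series", "measured", "known", "first", "only" and "open" are said of these compounds alone.

Working notes on the series. Compound 1 `COc1ccc(/C=C2\CN(C(=S)SCc3cn(Cc4ccccc4F)nn3)C/C(=C\c3ccc(OC)cc3)C2=O)cc1` and compound 2 `COc1ccc(/C=C2\CN(C(=S)SCc3cn(Cc4ccc(F)cc4)nn3)C/C(=C\c3ccc(OC)cc3)C2=O)cc1` share one core; compound 3 `O=C1/C(=C/c2ccccc2F)CN(C(=S)SCc2cn(Cc3ccccc3F)nn2)C/C1=C\c1ccccc1F` carries a different core, and the difference between the two cores is not broken down here. Compound 4 `O=C1/C(=C/c2ccccc2F)CN(C(=S)SCc2cn(Cc3ccc(F)cc3)nn2)C/C1=C\c1ccccc1F` has not yet been measured.

In a functional assay on MDA-MB-231 cells (Homo sapiens) for cytotoxicity, read by MTT assay, with a stated time of 24 h (on this read-out higher numbers stand for weaker inhibition and lower numbers for stronger inhibition), compound 1 gives > 100000 nM, which is a limit of the assay and not a number. In this assay compound 2 gives > 100000 nM, again a limit. In this assay, among the measured compounds shown here, compound 3 gives 57600 nM, the only number so far.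

The change 4-fluorophenyl in place of 2-fluorophenyl on a saturated chain carbon bound to an aromatic nitrogen gives a step that the two limits leave unreadable from compound 1 to compound 2, both ends sitting at the limit of > 100000 nM in this assay, at which 2 of the 3 values shown sit. The same change, (4-fluorophenyl in place of 2-fluorophenyl on a saturated chain carbon bound to an aromatic nitrogen), is made on the core of compound 3. With no readable precedent, the step from compound 3 to compound 4 is expected to be small, about a 1.0-fold higher number from compound 3 to compound 4 (0.02 log units; within the scatter). In this assay compound 4 is estimated at 60000 nM, from 25000 nM to 120000 nM.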

Compound 4, half-maximal inhibitory concentration: 58800 nM
For compound 4 the middle estimate is 1.0-fold (0.01 log units) above the measured one; measured number inside the range.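

In this assay, replacing 2-fluorobenzyl with 4-fluorobenzyl on the core of compound 3 gives a 1.0-fold higher number from compound 3 to compound 4 (0.01 log units; within the scatter). The same change on the core of compound 1 cannot be read, because compound 1 and compound 2 both stand at a limit of the assay and not at a number: the limit of > 100000 nM in this assay, at which 2 of the 4 values shown sit. The series therefore holds a single readable instance of this change, which does not show whether its size carries from one core to the other.

Still open, from the compounds shown here alone, is how the read-out responds when the fluorophenyl group gives way to a phenyl carrying an amine or a carboxylic acid. Going by these compounds, a longer chain on the aromatic nitrogen also remains open.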